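This account rests on a few compounds, and the source may have more. Where it says the series, first, only, none or still open, it means among the compounds named here.

Compound 1 `CCOC(=O)C12C(=O)OCC=C1COC2c1cccc(Cl)c1`: in a functional assay on QGY cells (Homo sapiens) for cytotoxicity, read by MTT assay (a lower number here means a stronger inhibitor, a higher number a weaker inhibitor), compound 1 gives > 1000000 nM, which is a limit of the assay and not a number.
Compound 2 `CCOC(=O)C12C(=O)OCC=C1COC2c1ccc(Cl)cc1`: in this assay compound 2 gives > 1000000 nM, again a limit of the assay.

Among the compounds with values here, compound 2 therefore stands at the limit, and the only other measured compound sits there too (the limit of > 1000000 nM in this assay, at which 2 of the 2 values shown sit). Within the data shown here, the one measured step at this position, a step that the two limits leave unreadable from compound 1 to compound 2, is hidden by those two limits, so it gives no size in either direction.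

Compound 3 `CCOC(=O)C12C(=O)OCC=C1COC2c1cccs1` differs from compound 2 by one change: thiophen-2-yl in place of 4-chlorophenyl on a saturated ring carbon. Among the measured compounds shown here, the sole step that bears on this position is the one from compound 1 to compound 2, and it cannot be read. Nothing in the measured pair suggests that an aromatic group on this saturated ring carbon moves the read-out off the limit, so no step beyond the scatter is expected in this assay. Compound 3 is accordingly expected to give roughly 1500000 nM, in a range from 300000 nM to 6000000 nM, most likely reported as a limit. The expected step is a step that the limit leaves unreadable from compound 2 to compound 3.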

Compound 3, half-maximal inhibitory concentration: > 1000000 nM
Compound 3: a limit, no number; the forecaster's own chance of this, stated with the estimate: 85%; the middle value does not contradict the limit.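

Within the data shown here, no step among compound 1, compound 2 and compound 3 can be read, since all three stand at the same limit of the assay, which is not a number: the limit of > 1000000 nM in this assay, at which 3 of the 3 values shown sit. The compounds shown leave open whether any group on this saturated ring carbon moves the read-out off that limit, and how far these three compounds truly differ.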